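Epimer of compound 1 at the pyrrolidine stereocentre

The compounds below may be only part of what the source reports. "The series", "measured", "known", "first", "only" and "open" are said of these compounds alone.

Measured so far:
compound 1 `CCN(CC)S(=O)(=O)c1ccc(S(=O)(=O)N2CCC[C@@H](C(=O)N[C@@H]3CCN(C(=O)OC(C)(C)C)C3)C2)cc1` gives 500 nM
compound 2 `CC(C)c1noc(N2CCN(C(=O)[C@@H]3CCCN(S(=O)(=O)c4ccc(S(=O)(=O)NC5CC5)cc4)C3)CC2)n1` gives 300 nM
compound 3 `CCOC(=O)[C@@H]1CCCN(S(=O)(=O)c2ccc(C(=O)N(CC)CC)cc2)C1` gives 100 nM

All three numbers come from a functional assay on MIA PaCa-2 cells (Homo sapiens) for inhibition, read by MTT assay, with a stated time of 3 days; a lower number here means a stronger inhibitor, a higher number a weaker inhibitor. Compound 1 has the highest number of the three. Its nearest neighbour is compound 2, whose number lies within the scatter of it, so the two cannot be ordered. Compound 3 has a number well beyond the scatter below compound 1. Within the data shown here, no two measured compounds differ in a single place, so no step of one change is available from the measured set, and the effect of the carbonyl-bearing amide partner or of the aryl substituents cannot be separated.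

Compound 4 `CCN(CC)S(=O)(=O)c1ccc(S(=O)(=O)N2CCC[C@@H](C(=O)N[C@H]3CCN(C(=O)OC(C)(C)C)C3)C2)cc1` is the next compound. Relative to compound 1, the change is: the two compounds have the same atoms and bonds and differ only in configuration as drawn: 1 of 2 stereo elements differ; a stereocentre at a saturated ring carbon is drawn R in compound 1 and S in compound 4. Nothing measured here speaks to a change of configuration at that centre, so the direction is open. The step is expected to be no change at the digits printed from compound 1 to compound 4 (within the scatter), with no shift beyond the scatter expected in either direction. Compound 4 is therefore estimated at 500 nM, with a range from 150 nM to 2000 nM.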

Compound 4, half-maximal inhibitory concentration: 170 nM
Estimate against measurement, compound 4: 2.9-fold (0.47 log units) above; the range from low to high includes it.
By their numbers in this assay, from the lowest: compounds 3, 4, 2 and 1 (each within the scatter of the next, the first and the last beyond it).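

In this assay, among these compounds, the stereocentre at a saturated ring carbon is the first position with a readable effect: going from R to S gives a 2.9-fold lower number from compound 1 to compound 4 (0.47 log units; beyond the scatter), a modest step. The earlier compounds shown here differed in several places at once, whereas this step can be assigned to configuration at this one centre because no atom or bond changes: the fact that compounds 1 and 4 differ only in the configuration as drawn. Configuration at this carbon alone is therefore enough to move the number beyond the scatter, with the S form giving the lower number in this pair.

On these data alone, whether the same ordering of R and S holds when the tert-butyl carbamate gives way to a free amine or an acetyl group remains open. Also open, as far as these compounds go, is the effect of inverting the other stereocentre, alone or together with this one.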